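A few compounds are considered here, and "the series" means these few. Any claim that something is new, unique, unknown or untested is made for them only; others in the source may bear on it.

The compounds here share one core and differ only in the aryl group carried on a saturated ring carbon. Compound 1 `FC(F)(F)c1ccc(C2CC(c3ccc4c(c3)OCCO4)=NN2c2ccccc2)cc1` carries a 4-(trifluoromethyl)phenyl there. In a functional assay on WM 266-4 cells (Homo sapiens) for antiproliferative activity, read by MTT assay, with a stated time of 24 h (a higher number here means a weaker inhibitor of growth, a lower number a stronger inhibitor of growth), compound 1 gives only a limit, > 100000 nM, and so stands at the limit of > 100000 nM in this assay, at which 1 of the 3 values shown sits. Compound 2 `COc1ccc(C2CC(c3ccc4c(c3)OCCO4)=NN2c2ccccc2)cc1OC` carries a 3,4-dimethoxyphenyl instead, and in this assay compound 2 gives 2160 nM. Compound 3 `Ic1ccc(C2CC(c3ccc4c(c3)OCCO4)=NN2c2ccccc2)cc1` carries a 4-iodophenyl, and in this assay compound 3 gives 3470 nM. Both steps away from compound 1 are large: an at least 46-fold lower number from compound 1 to compound 2 (1.66 log units; beyond the scatter) and an at least 28-fold lower number from compound 1 to compound 3 (1.45 log units; beyond the scatter). Between the two measured numbers themselves there is a 1.6-fold higher number from compound 2 to compound 3 (0.21 log units; within the scatter).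

Compound 4 `Cc1ccc(C2CC(c3ccc4c(c3)OCCO4)=NN2c2ccccc2)cc1` has not yet been measured. It differs from compound 1 in one place: methyl in place of trifluoromethyl on an aromatic carbon. The measured steps that bear on this change are the two that remove the trifluoromethyl from compound 1, and both were large and both ran to lower numbers. Replacing the trifluoromethyl with a methyl is therefore expected to give a downward step as well, estimated as an at least 20-fold lower number from compound 1 to compound 4 (1.30 log units; beyond the scatter). Compound 4 is estimated in this assay at 5000 nM, with a likely range from 1500 nM to 30000 nM.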

Compound 4, concentration for 50% growth inhibition: 2530 nM
Estimate against measurement, compound 4: 2.0-fold (0.30 log units) above, within the range that was stated.
By their numbers in this assay, from the lowest: compounds 2, 4 and 3 (each within the scatter of the next). At a limit, above all of these: compound 1.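

Compound 4 keeps one carbon at this place on the aromatic ring and loses only the three fluorine atoms, and that small change alone gives an at least 39-fold lower number from compound 1 to compound 4 (1.59 log units; beyond the scatter). The new compound also falls in with the two other measured compounds, with a 1.4-fold lower number from compound 3 to compound 4 (0.14 log units; within the scatter) and a 1.2-fold higher number from compound 2 to compound 4 (0.07 log units; within the scatter), so in this assay the methyl, iodo and 3,4-dimethoxyphenyl compounds cannot be told apart, and among the four compounds only compound 1 stands away from them. The value for compound 1 is a limit and not a number, so each step from it gives only a minimum size: the limit of > 100000 nM in this assay, at which 1 of the 4 values shown sits.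

The compounds shown leave open whether other groups at this place, such as an amine, a carboxylic acid or a longer chain like butyl, would stay with compounds 2, 3 and 4 or would reach a limit as compound 1 does. They also leave open whether a single fluorine or a nitrile would behave like the methyl or like the trifluoromethyl, and these numbers give no reason why the trifluoromethyl stands apart.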